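This account rests on a few compounds, and the source may have more. Where it says the series, first, only, none or still open, it means among the compounds named here.

Compound 1 `COc1cccc(/C=C2\CCC/C(=C\c3cccc(Cl)c3)C2=O)c1OC`: 21400 nM
Compound 2 `COc1cccc(/C=C2\CCC/C(=C\c3cccc(Br)c3)C2=O)c1OC`: 23900 nM
Compound 3 `COc1cccc(/C=C2\CCC/C(=C\c3cccc(O)c3)C2=O)c1OC`: 19300 nM

In an ADME assay on NHDF cells (Homo sapiens) for cytotoxicity, read by MTT assay, with a stated time of 72 h (a lower number here means a stronger inhibitor, a higher number a weaker inhibitor), compound 3 gives 19300 nM and stands level with the other two compounds, since its steps to both lie within the scatter. Compound 4 `COc1cccc(/C=C2\CCC/C(=C\c3cccc(Cl)c3Cl)C2=O)c1OC` changes one group of compound 3: 2,3-dichlorophenyl in place of 3-hydroxyphenyl on a double-bonded chain carbon bound to a double-bonded ring carbon. Among the measured compounds shown here, three measured steps bear on this, and each swaps one group on that same aromatic ring: a 1.1-fold higher number from compound 1 to compound 2 (0.05 log units; within the scatter), a 1.1-fold lower number from compound 1 to compound 3 (0.04 log units; within the scatter) and a 1.2-fold lower number from compound 2 to compound 3 (0.09 log units; within the scatter). For the measured compounds named here, all three are small, but no measured compound carries the 2,3-dichlorophenyl group, so the estimate stays uncertain. The expected change is therefore none beyond the scatter, an estimated 1.0-fold higher number from compound 3 to compound 4 (0.02 log units; within the scatter). The estimated value for compound 4 is 20000 nM, with an expected range of 10000 nM to 40000 nM.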

Compound 4, half-maximal inhibitory concentration: > 50000 nM
Compound 4 gave a limit, no number; the forecaster's own chance of this, stated with the estimate: 5%; at least 2.5-fold (0.39 log units) between middle value and limit.
By their numbers in this assay, from the lowest: compounds 3, 1 and 2 (each within the scatter of the next). At a limit, above all of these: compound 4.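

In this assay compound 4 gives a limit, not a number: the limit of > 50000 nM in this assay, at which 1 of the 4 values shown sits.

The earlier swaps on this ring all stayed within the scatter, but this change goes beyond it, with an at least 2.5-fold higher number from compound 3 to compound 4 (0.41 log units; beyond the scatter) and an at least 2.0-fold higher number from compound 2 to compound 4 (0.32 log units; beyond the scatter). Adding a single group is enough, as chloro in place of hydrogen on an aromatic carbon gives an at least 2.3-fold higher number from compound 1 to compound 4 (0.36 log units; beyond the scatter).

From the compounds shown here alone, whether a methyl or an amine in place of that added chloro would give the same rise remains open. Going by these compounds, the true size of these steps also remains open.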